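Fluoro for chloro on the aryl ring, two-carbon linker kept

The source may hold more compounds than are shown below. What is called first, only, known or untested is meant among the compounds shown, and "the series" means these compounds.

Measured compounds:
Compound 1 `NS(=O)(=O)NCC1CCN(c2cc(-c3ccccc3F)ncn2)CC1`: 48500 nM
Compound 2 `NS(=O)(=O)NCCC1CCN(c2cc(-c3ccccc3Cl)ncn2)CC1`: 44800 nM

In a functional assay on MCF7 cells (Homo sapiens) for antiproliferative activity, read by sulforhodamine B assay, with a stated time of 48 h (a lower number here means a stronger inhibitor of growth, a higher number a weaker inhibitor of growth), compound 2 gives 44800 nM, numerically the lower of the two values, but its gap to compound 1 lies within the usual scatter, so the two compounds cannot be told apart on these numbers. Compound 3 `NS(=O)(=O)NCCC1CCN(c2cc(-c3ccccc3F)ncn2)CC1` has not been measured. It differs from compound 2 by fluoro in place of chloro on an aromatic carbon; the linker of two carbons between the sulfamide nitrogen and the piperidine ring is unchanged. Among the measured compounds shown here, no pair of measured compounds isolates this exchange, so the step has no precedent here. Compound 1 carries the same fluoro group with a shorter linker and sits within the scatter of compound 2, which gives no hint of a large effect. The step of a 1.0-fold higher number from compound 2 to compound 3 (0.02 log units; within the scatter) is therefore expected to be small, in no clear direction, and not beyond the scatter. For compound 3 the estimate in this assay is 47000 nM, within 20000 nM to 110000 nM.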

Compound 3, concentration for 50% growth inhibition: > 100000 nM
Compound 3 ended at the assay's limit; the forecaster's own chance of this, stated with the estimate: 10%; middle value at least 2.1-fold (0.32 log units) from the limit.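

In this assay compound 3 stands at a limit of the assay and not at a number: the limit of > 100000 nM in this assay, at which 1 of the 3 values shown sits.

Fluoro in place of chloro on this aromatic carbon, ortho to a large group, is not a silent exchange with the two-carbon linker kept: the change gives an at least 2.2-fold higher number from compound 2 to compound 3 (0.34 log units; beyond the scatter). With fluoro held constant, the linker matters as well, as (sulfamoylamino)methyl in place of sulfamoylamino gives an at least 2.0-fold higher number from compound 1 to compound 3 (0.31 log units; beyond the scatter), so the two groups do not act independently of each other in this small set.

From the compounds shown here alone, the full size of both steps stays open, as each is bounded by the limit. Also open, going by these compounds, is how a bromo or methyl group at this aromatic carbon, or a longer chain in the linker, would read in this assay.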